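From an oxane ester to a hydroxyethyl ether

This account rests on a few compounds, and the source may have more. Where it says the series, first, only, none or still open, it means among the compounds named here.

Compound 3 `CC(C)=CC[C@@H](OC(=O)C1CCCCO1)C1=CC(=O)c2c(O)ccc(O)c2C1=O` carries an (oxan-2-yl)carbonyl ester on the shared core. In a functional assay on HeLa cells (Homo sapiens) for cytotoxicity, read by MTT assay (on this read-out lower numbers stand for stronger inhibition and higher numbers for weaker inhibition), compound 3 gives only a limit, > 100000 nM. Its two measured relatives give numbers: in this assay compound 1 `CC(C)=CC[C@@H](OC(=O)CC(C)(O)c1ccccc1)C1=CC(=O)c2c(O)ccc(O)c2C1=O` gives 85700 nM, and compound 2 `CC(C)=CC[C@@H](OC(=O)C1CCCO1)C1=CC(=O)c2c(O)ccc(O)c2C1=O` gives 17000 nM. The steps into compound 3 read an at least 1.1-fold higher number from compound 1 to compound 3 (0.06 log units; that floor lies within the scatter) and an at least 5.8-fold higher number from compound 2 to compound 3 (0.76 log units; beyond the scatter), so compound 3 stands at the weak end of the three, sitting at the limit of > 100000 nM in this assay, at which 1 of the 3 values shown sits, while its gap from compound 1 stays unresolved. Compound 4 `CC(C)=CC[C@@H](OCCO)C1=CC(=O)c2c(O)ccc(O)c2C1=O` differs from compound 3 as follows: 2-hydroxyethyl in place of (oxan-2-yl)carbonyl on an oxygen on a saturated carbon. Among the compounds with values here, all three measured compounds keep the carbonyl on that oxygen, and every measured step only swaps the group on the carbonyl carbon; no measured step therefore bears directly on this change. Given that the numbers seen so far span only from compound 2 upward to the limit of compound 3, compound 4 is expected to land in the same weak region, with the step of an at least 1.4-fold lower number from compound 3 to compound 4 (0.15 log units; that floor lies within the scatter) estimated to fall within the scatter. Compound 4 is estimated at 70000 nM, in a range from 15000 nM to 300000 nM.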

Compound 4, half-maximal inhibitory concentration: 18600 nM
Beside the measured number, compound 4's estimate is 3.8-fold (0.58 log units) above it, and the stated range covers the measured number.
By their numbers in this assay, from the lowest: compounds 2 and 4 (each within the scatter of the next); then compound 1. At a limit, above all of these: compound 3.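

In this assay, the first change shown at this oxygen itself, 2-hydroxyethyl in place of (oxan-2-yl)carbonyl, gives an at least 5.3-fold lower number from compound 3 to compound 4 (0.73 log units; beyond the scatter). A carbonyl on this oxygen is therefore not needed for a measured number on the shared core, and 2-hydroxyethyl stands level with (oxolan-2-yl)carbonyl, at a 1.1-fold higher number from compound 2 to compound 4 (0.04 log units; within the scatter). Compound 3 remains a limit of the assay, so the full size of the first step cannot be read: the limit of > 100000 nM in this assay, at which 1 of the 4 values shown sits.

The compounds shown leave open whether the hydroxyl of the 2-hydroxyethyl group counts, which a plain ethyl or a longer chain such as 3-hydroxypropyl on this oxygen would test. They also leave open how an aminoethyl or a carboxymethyl group on this oxygen would read in this assay.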